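A few compounds are considered here, and "the series" means these few. Any claim that something is new, unique, unknown or untested is made for them only; others in the source may bear on it.

Compound 1 `COc1cccc(/C=C2\CCC/C(=C\c3ccccc3Br)C2=O)c1OC`: > 50000 nM, a limit and not a number.
Compound 2 `COc1ccc(/C=C2\CCC/C(=C\c3cccc(OC)c3OC)C2=O)cc1`: 43500 nM.

Both compounds were tested in an ADME assay on NHDF cells (Homo sapiens) for cytotoxicity, read by MTT assay, with a stated time of 72 h; a lower number here means a stronger inhibitor, a higher number a weaker inhibitor. Compound 1 therefore has no exact position on this scale, only (the limit of > 50000 nM in this assay, at which 1 of the 2 values shown sits).

Compound 3 `COc1cccc(/C=C2\CCC/C(=C\c3ccc(O)cc3)C2=O)c1OC` has not yet been measured. It keeps the core of compound 1 and changes one group: 4-hydroxyphenyl in place of 2-bromophenyl on a double-bonded chain carbon bound to a double-bonded ring carbon. Within the data shown here, one measured step bears on this change, as it alters the same place on the molecule. Putting 4-methoxyphenyl in place of 2-bromophenyl gave an at least 1.1-fold lower number from compound 1 to compound 2 (0.06 log units; that floor lies within the scatter), a floor that does not rise above the usual scatter. The group entering in compound 3 is 4-hydroxyphenyl rather than 4-methoxyphenyl, so this step is only a rough guide.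

Given the size of an at least 1.1-fold lower number from compound 1 to compound 2 (0.06 log units; that floor lies within the scatter), no step beyond the scatter is expected in this assay, though any shift would more likely be toward a lower number. The estimated change is an at least 1.2-fold lower number from compound 1 to compound 3 (0.09 log units; that floor lies within the scatter). For compound 3 the expected value is 40000 nM, with an estimated range from 15000 nM to 70000 nM.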

Compound 3, half-maximal inhibitory concentration: > 50000 nM
Compound 3 ended at the assay's limit; the forecaster's own chance of this, stated with the estimate: 35%; middle value at least 1.2-fold (0.09 log units) away from the limit.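

Putting hydrogen in place of methyl on the oxygen of the 4-methoxyphenyl group gives an at least 1.1-fold higher number from compound 2 to compound 3 (0.06 log units; that floor lies within the scatter), so this small edit, which brings in a hydrogen-bond donor, shows no step beyond the scatter in this assay, although a floor does not fix the true size of the step. The result also adds a third group at this place, on a double-bonded chain carbon bound to a double-bonded ring carbon, and 4-hydroxyphenyl joins 2-bromophenyl at the top of the scale, even though the two groups share little beyond their aromatic ring. The step between these two compounds cannot be read, because each carries a limit and not a number: the limit of > 50000 nM in this assay, at which 2 of the 3 values shown sit.

Going by these compounds, how far compound 1 and compound 3 actually lie past that limit remains unknown, so any real difference between them stays hidden. On these data alone, it is also open whether a different group on the same phenyl ring, such as an amine or a carboxylic acid in place of the hydroxyl, would give a step beyond the scatter in this assay.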